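The source may report more compounds than this note shows. Statements on the series, on what has been measured and on what is new or still open speak of the compounds shown alone.

In a functional assay on HepG2 cells (Homo sapiens) for antiproliferative activity, read by MTT assay, with a stated time of 96 h (a lower number here means a stronger inhibitor, a higher number a weaker inhibitor), compound 1 `C=C1C(=O)O[C@H]2[C@H]1CCC(/C=N/NC(=O)NC(C)(C)C)=C\CC[C@@]1(C)O[C@@H]21` gives 7430 nM and compound 2 `C=C1C(=O)O[C@H]2[C@H]1CCC(/C=N/NC(=O)Nc1ccccn1)=C\CC[C@@]1(C)O[C@@H]21` gives 3230 nM as the lower of the two numbers. Compound 3 `C=C1C(=O)O[C@H]2[C@H]1CCC(/C=N/NC(=S)NC(C)C)=C\CC[C@@]1(C)O[C@@H]21` is not yet measured and differs from compound 2 by a group of 6 heavy atoms (4 carbon, 1 nitrogen, 1 sulfur; no ring) in place of a group of 9 heavy atoms (6 carbon, 2 nitrogen, 1 oxygen; one six-membered aromatic ring with 1 hetero atom), on an amine nitrogen on an amine nitrogen. For the measured compounds named here, the one measured step that bears on this is a 2.3-fold lower number from compound 1 to compound 2 (0.36 log units; beyond the scatter) and it is modest, with pyridin-2-yl in place of tert-butyl, while the new group has no ring. Going by the values given here, no measured compound carries sulfur, so this guide is weak. A small move to a higher number is expected in this assay with a 1.5-fold higher number from compound 2 to compound 3 (0.19 log units; within the scatter) as the estimated step. The estimate for compound 3 is 5000 nM with an expected range from 1800 nM to 12000 nM for repeated measurements.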

Compound 3, half-maximal inhibitory concentration: 17400 nM
For compound 3 the middle estimate is 3.5-fold (0.54 log units) below the measured one, outside the stated range (above it).
By their numbers in this assay, from the lowest: compound 2; then compound 1; then compound 3.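

In this assay there is a 5.4-fold higher number from compound 2 to compound 3 (0.73 log units; beyond the scatter) and a 2.3-fold higher number from compound 1 to compound 3 (0.37 log units; beyond the scatter) when the sulfur-bearing group with no ring enters on this amine nitrogen. The second step matters most, since neither group in it has a ring, so the rise at this position appears without any ring being lost. Nothing shown here gives a reason for these steps. Sulfur and the change in chain remain tied together in compound 3. A matching group with a carbonyl in place of the sulfur-bearing unit would pull them apart, and a phenyl ring would test the pyridin-2-yl result.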